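Swapping a methoxy for a cyano on a cell viability read-out

The source may hold more compounds than are shown below. What is called first, only, known or untested is meant among the compounds shown, and "the series" means these compounds.

Compound 1 has the structure `COc1cccc(Nc2nc(Oc3cccc(NC(=O)C=C(C)C)c3)c3sccc3n2)c1`. In an ADME assay on L02 cells (Homo sapiens) for inhibition, read by MTT assay, with a stated time of 72 h (on this read-out lower numbers stand for stronger inhibition and higher numbers for weaker inhibition), compound 1 shows "not determined" (no result reported), so no number places it on the scale. Its close relative compound 2, with the structure `COc1cccc(Nc2nc(Oc3cccc(NC(=O)/C=C/C(C)C)c3)c3sccc3n2)c1`, likewise shows "not determined" (no result reported) in this assay. The only reported figure comes from compound 3, whose structure is `CCC/C=C/C(=O)Nc1cccc(Oc2nc(Nc3cccc(OC)c3)nc3ccsc23)c1`. In this assay compound 3 reaches only a limit of the measurement, > 50000 nM, and not a number. This is the sense in which compound 1 stands among the values shown: one further entry is a limit and one further entry is empty, with no single number anywhere, as the line the limit of > 50000 nM in this assay, at which 1 of the 3 values shown sits, summarises.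

Compound 4, with the structure `CC(C)=CC(=O)Nc1cccc(Oc2nc(Nc3cccc(C#N)c3)nc3ccsc23)c1`, differs from compound 1 in one place: cyano in place of methoxy on an aromatic carbon. Among the compounds with values here, no measured pair reports a step in this assay, so the size of the step from compound 1 to compound 4 has nothing to rest on. The one reported entry, the limit of compound 3, suggests the series as a whole sits at the weak end of this assay, and the expectation for compound 4 is no inhibition beyond the scatter. Compound 4 is therefore expected to give about 50000 nM, estimated between 20000 nM and 100000 nM, most likely again as a limit.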

Compound 4, half-maximal inhibitory concentration: > 50000 nM
Compound 4 gave a limit, no number (the forecaster's own chance of this, stated with the estimate: 70%); the middle value sits exactly at the limit.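

In this assay compound 4 gives > 50000 nM, which is a limit of the assay and not a number. Within the data shown here, compound 1 has no number on this scale, so no step between compound 1 and compound 4 can be read. From the compounds shown here alone, whether cyano in place of methoxy changes this read-out at all remains open.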